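Replacing trifluoromethyl with fluoro on a salicylanilide scaffold

A few compounds are considered here, and "the series" means these few. Any claim that something is new, unique, unknown or untested is made for them only; others in the source may bear on it.

Three salicylanilides have been tested in an ADME assay on cells (Macrophage, Mus musculus) for cytotoxicity, read by resazurin assay, with a stated time of 3 days; on this read-out lower numbers stand for stronger inhibition and higher numbers for weaker inhibition. Compound 1 `O=C(Nc1cccc(C(F)(F)F)c1F)c1cc(Cl)ccc1O` gives 5300 nM, compound 2 `O=C(Nc1cccc(F)c1F)c1cc(Cl)ccc1O` gives 13000 nM, and compound 3 `O=C(Nc1cc(C(F)(F)F)ccc1Cl)c1cc(Cl)ccc1O` gives 3500 nM. The change from compound 1 to compound 2 is fluoro in place of trifluoromethyl on an aromatic carbon; it produced a 2.5-fold higher number from compound 1 to compound 2 (0.39 log units; beyond the scatter), a weakening of cytotoxicity. The difference between the core of compound 1 and the core of compound 3 is not broken down here.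

Compound 4 `O=C(Nc1cc(F)ccc1Cl)c1cc(Cl)ccc1O` has not yet been measured. It differs from compound 3 by fluoro in place of trifluoromethyl on an aromatic carbon. For the measured compounds named here, this is the same kind of change as the one from compound 1 to compound 2, but not the same: in compound 1 the leaving group sits ortho to a fluoro group and meta to a large group, while in compound 3 it sits meta to a large group and para to a chloro group.

Because a 2.5-fold higher number from compound 1 to compound 2 (0.39 log units; beyond the scatter) weakened cytotoxicity, a similar step is expected from compound 3 to compound 4, namely a 2.4-fold higher number from compound 3 to compound 4 (0.39 log units; beyond the scatter). Compound 4 is therefore estimated at 8500 nM in this assay, expected to lie between 4000 nM and 18000 nM.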

Compound 4, half-maximal inhibitory concentration: 3200 nM
Compound 4: middle estimate off by 2.7-fold (0.42 log units), on the high side; the measured number lies below the stated range.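

In this assay, the swap of trifluoromethyl for fluoro on the core of compound 3 gives a 1.1-fold lower number from compound 3 to compound 4 (0.04 log units; within the scatter), so on this core the change leaves no difference that can be told from assay noise. The change therefore does not carry over at the same size from one core to the other: the same change on two cores in this assay, a 2.5-fold higher number (0.39 log units; beyond the scatter) from compound 1 to compound 2 and a 1.1-fold lower number (0.04 log units; within the scatter) from compound 3 to compound 4, 2.7-fold (0.43 log units) apart, beyond the scatter of two such steps. This shows that a step seen on one core of this series cannot simply be transferred to another, but with one pair on each of two cores, it does not show which feature of the cores sets the size of the step.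

Open, going by these compounds, is how a methyl group, a nitrile or an amine would compare with trifluoromethyl and fluoro in the same place on either core. Also open, on these data alone, is whether a third core would behave like the core of compound 1, like the core of compound 3, or like neither.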